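Replacing pyridin-4-yl with pyrimidin-5-yl on a shared core

A few compounds are considered here, and "the series" means these few. Any claim that something is new, unique, unknown or untested is made for them only; others in the source may bear on it.

This short series keeps one core and varies only the aromatic ring at the end of the chain. Compound 1 has the structure `COc1ccc(S(=O)(=O)/C=C/c2ccccn2)cc1` and in an ADME assay on microsomes from liver (Homo sapiens) for metabolic stability, read by LC-MS, using NADPH, with stated times of 5 min and 30 min, tested at 1 uM (a lower number here means that less of the compound is left, a higher number that more of the compound is left), compound 1 gives 56%. Compound 2, with the structure `COc1ccc(S(=O)(=O)/C=C/c2cccnc2)cc1`, and compound 3, with the structure `COc1ccc(S(=O)(=O)/C=C/c2ccncc2)cc1`, share that core but carry their ring nitrogen in a different position. For compound 2 the result in this assay is recorded as "not determined" (no result reported). For compound 3 the result in this assay is recorded as "not determined" (no result reported), so compound 3 stands without a number among the values shown, and compound 2 likewise has none.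

Compound 4, with the structure `COc1ccc(S(=O)(=O)/C=C/c2cncnc2)cc1`, is the next step from compound 3. The change is pyrimidin-5-yl in place of pyridin-4-yl on a double-bonded chain carbon bound to a double-bonded chain carbon. For the measured compounds named here, no measured pair in this set shows what such a change does, so the expectation can only lean on the one number available, that of compound 1. A step of modest size, within the scatter or only just beyond it, is expected in this assay, with no clear direction. On that basis compound 4 is estimated to give about 55% in this assay, with a range from 35% to 75%.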

Compound 4, percent of the compound remaining: 94%
Compound 4: the middle estimate sits 39 percentage points below what was measured, and the stated range ends below it.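

Exchanging the ring at the end of the chain for pyrimidin-5-yl gives, in this assay, a number 38 percentage points higher from compound 1 to compound 4 (beyond the scatter). For the compounds shown here, this is the first readable step, and it shows that the ring at the end of the chain is not a passive part of these molecules: with the rest of the structure unchanged, exchanging one six-membered aromatic ring for another of the same heavy-atom count is enough to leave clearly more of the compound at the end of the assay. The data shown give no explanation for this rise, so the change can be described but its cause cannot be assigned.

Steps involving compound 2 or compound 3 cannot be read, since neither has a number here, so the single step available cannot separate the effect of the second ring nitrogen from that of moving the ring's attachment relative to its nitrogen. Also open, as far as these compounds go, is how this read-out would respond at the same place to a phenyl ring, with carbon alone in the ring, or to a pyrimidin-5-yl ring bearing an amine.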